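A Chloro Group on a Mostly Inactive Core

The source may hold more compounds than are shown below. What is called first, only, known or untested is meant among the compounds shown, and "the series" means these compounds.

- compound 1 `c1ccc(-c2ccc(-c3ccc(-c4nc5ccccc5[nH]4)cc3)cc2)cc1`: 100000 nM
- compound 2 `COc1ccc(-c2ccc(-c3ccc(-c4nc5cc(C)ccc5[nH]4)cc3)cc2)cc1OC`: 2120 nM
- compound 3 `FC(F)(F)Oc1ccc(-c2ccc(-c3ccc(-c4nc5ccccc5[nH]4)cc3)cc2)cc1`: 100000 nM

In a functional assay on HOP-62 cells (Homo sapiens) for inhibition, read by sulforhodamine B assay (on this read-out lower numbers stand for stronger inhibition of growth and higher numbers for weaker inhibition of growth), compound 1 gives 100000 nM. Compound 3 sits level with it, and compound 2 has a clearly lower number, which means stronger inhibition of growth. So compound 1 stands at the weak end of this small set.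

The next compound to be tested is compound 4 `Clc1cccc(-c2ccc(-c3ccc(-c4nc5ccccc5[nH]4)cc3)cc2)c1`. It comes from compound 1 by one small change, chloro in place of hydrogen on an aromatic carbon.

Going by the values given here, only one measured step resembles this change, since it also replaces a single hydrogen on an aromatic carbon, here with trifluoromethoxy: no change at the digits printed from compound 1 to compound 3 (within the scatter). Among the compounds with values here, one step is thin evidence, and no measured compound carries a chloro group. Still, it gives no reason to expect a real shift in this assay, so no step beyond the scatter is expected.

The expected step is a 1.3-fold lower number from compound 1 to compound 4 (0.10 log units; within the scatter). Compound 2 at 2120 nM shows that lower numbers do occur among these compounds, so the range stays open downward. Compound 4 is estimated at 80000 nM, with an expected range from 15000 nM to 100000 nM.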

Compound 4, concentration for 50% growth inhibition: 100000 nM
Compound 4: the middle estimate sits 1.3-fold (0.10 log units) below what was measured; the measured number falls inside the stated range.
By their numbers in this assay, from the lowest: compound 2; then compounds 1, 3 and 4 (each within the scatter of the next).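

In this assay, going by these compounds alone, placing chloro on an aromatic carbon of a six-membered aromatic ring of carbon only, meta to a large group, gives no change at the digits printed from compound 1 to compound 4 (within the scatter) and so provides the first reading for a chloro group on the shared core. Together with the earlier no change at the digits printed from compound 1 to compound 3 (within the scatter), this makes two different single-group replacements of hydrogen on compound 1, and neither moves the printed number, although the phenyl to 3-chlorophenyl change fixes one particular place for the new group. Nothing measured here bears on why the number stays level with that of compound 1.

On these data alone, it remains open whether a group of another kind on this same ring, such as an amine, a carboxylic acid or a longer chain, would shift the number away from the level of compound 1 at all. As far as these compounds go, it also remains open whether a chloro group would leave the number unchanged on a compound that already reads lower, such as compound 2 at 2120 nM, where any step in either direction could be seen against a stronger starting point.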